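This account rests on a few compounds, and the source may have more. Where it says the series, first, only, none or still open, it means among the compounds named here.

Two compounds share one core and differ only in the chain attached to the amine nitrogen. Compound 1 `NCCCCN(C[C@@H]1Cc2ncccc2CN1)[C@H]1CCCc2cccnc21` and compound 2 `NC/C=C\CN(C[C@H]1Cc2ncccc2CN1)[C@H]1CCCc2cccnc21` have both been tested in an ADME assay for permeability, using PAMPA, with a stated time of 4 h, at pH 5.5; on this read-out higher numbers stand for higher permeability and lower numbers for lower permeability. Compound 1 gives 2 nm/s, while compound 2 gives 28 nm/s, the higher of the two numbers, and that gap lies beyond the usual scatter of the measurement.

Compound 3 `CN(C)CCCCN(C[C@H]1Cc2ncccc2CN1)[C@H]1CCCc2cccnc21` has not yet been measured. It differs from compound 2 by a single change: 3-(dimethylamino)propyl in place of 3-aminoprop-1-en-1-yl on a saturated chain carbon bound to an amine nitrogen. The chain that enters is longer by two heavy atoms, has no double bond and carries no hydrogen-bond donor, whereas the chain that leaves carries one.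

Among the compounds with values here, with only two measured compounds, no steady trend can be claimed. Since compound 1, with a saturated chain bearing a donor, gives 2 nm/s and compound 2 gives 28 nm/s, the saturated but donor-free chain of compound 3 is expected to sit near compound 2 rather than near compound 1. The step from compound 2 to compound 3 is therefore estimated as a 1.3-fold higher number from compound 2 to compound 3 (0.10 log units; within the scatter), not beyond the scatter. For compound 3 the expected value in this assay is 35 nm/s, with a likely range from 8 nm/s to 120 nm/s.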

Compound 3, apparent permeability: 2 nm/s
Compound 3: the middle estimate sits 18-fold (1.24 log units) above what was measured; measured number outside the range, below it.
By their numbers in this assay, from the lowest: compounds 1 and 3 (each within the scatter of the next); then compound 2.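

In this assay, this position on a saturated chain carbon bound to an amine nitrogen proves sensitive to the swap of 3-aminoprop-1-en-1-yl for 3-(dimethylamino)propyl, with a 14-fold lower number from compound 2 to compound 3 (1.15 log units; beyond the scatter), a large step for one change. The absence of a hydrogen-bond donor on the entering chain therefore does not by itself keep the number at the level of compound 2, as compound 3 has no donor on that chain and still gives 2 nm/s. The change also adds two heavy atoms and removes the double bond, and no measurement shown here ties the step to any one of these differences.

Still open, as far as these compounds go, is which of these three differences matters, as all of them arrive together in this single step. A 4-(dimethylamino)but-2-en-1-yl chain would keep the double bond while carrying the same dimethylamino end, and a saturated 4-aminobutyl chain on the same stereoisomer as compound 2 would keep the primary amine without the double bond, so each would test one part of the change on its own.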